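A Methoxy for a Methyl on the Aromatic Ring

The compounds below may be only part of what the source reports. "The series", "measured", "known", "first", "only" and "open" are said of these compounds alone.

Compound 2 `Cc1ccc(CNc2ncc(C(=O)O)c3nc(-c4ccco4)nn23)cc1` carries a 4-methylbenzyl group on the shared core, and in an assay on CHO cells for displacement of a labelled ligand from adenosine receptor A1 (Homo sapiens) (on this read-out higher numbers stand for weaker inhibition and lower numbers for stronger inhibition), compound 2 gives 2730 nM. Compound 1 `CCNc1ncc(C(=O)O)c2nc(-c3ccco3)nn12` has an ethyl chain in that place; in this assay compound 1 gives 11900 nM. The step of a 4.4-fold lower number from compound 1 to compound 2 (0.64 log units; beyond the scatter) is the only measured one, and it leaves compound 2 with the lowest of the two numbers, compound 1 being its nearest neighbour. Compound 3 `COc1ccc(CNc2ncc(C(=O)O)c3nc(-c4ccco4)nn23)cc1` differs from compound 2 by methoxy in place of methyl on an aromatic carbon. Among the compounds with values here, no measured step concerns a change of this kind: the single step of a 4.4-fold lower number from compound 1 to compound 2 (0.64 log units; beyond the scatter) exchanges the whole 4-methylphenyl against a methyl at the chain end, not one substituent on that ring, so the series offers no direct guide. Within the data shown here, with no bearing step, the change is expected to leave the number near that of compound 2, and compound 3 is expected to show a 1.1-fold lower number from compound 2 to compound 3 (0.04 log units; within the scatter), a step not beyond the scatter in either direction. For compound 3 the estimate in this assay is 2500 nM, within a range from 900 nM to 7000 nM.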

Compound 3, inhibition constant: 5760 nM
Estimate against measurement, compound 3: 2.3-fold (0.36 log units) below; measured number inside the range.
By their numbers in this assay, from the lowest: compound 2; then compound 3; then compound 1.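

In this assay, the exchange on an aromatic carbon para to a large group is not silent: methoxy in place of methyl gives a 2.1-fold higher number from compound 2 to compound 3 (0.32 log units; beyond the scatter). The earlier pair exchanged the whole 4-methylphenyl against a methyl at the chain end, so only now is it seen that one substituent on that ring can move the number beyond the scatter. The 4-methoxybenzyl group still keeps its number under that of the ethyl chain, with a 2.1-fold lower number from compound 1 to compound 3 (0.32 log units; beyond the scatter), but this is a smaller step than a 4.4-fold lower number from compound 1 to compound 2 (0.64 log units; beyond the scatter), so the lower number seen with the 4-methylbenzyl group depends in part on what that ring carries. Nothing available explains why methoxy gives the higher number here.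

The compounds shown leave open how a benzyl group with a hydrogen at this place, or with chloro, hydroxyl or an amine there, would compare with the methyl and methoxy compounds. They also leave open whether the same exchange of methyl for methoxy would give a step of like size and direction on a core bearing a methyl ester or an amide in place of the carboxylic acid.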